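The source may hold more compounds than are shown below. What is called first, only, known or untested is meant among the compounds shown, and "the series" means these compounds.

The measured compounds:
- compound 1, `Fc1ccc(C2=NN(C(=S)Nc3ccccc3)C(c3ccc4c(c3)OCCO4)C2)cc1`; in a functional assay on HT-29 cells (Homo sapiens) for antiproliferative activity, read by MTT assay, with a stated time of 48 h (on this read-out higher numbers stand for weaker inhibition of growth and lower numbers for stronger inhibition of growth), compound 1 gives 37600 nM.
- compound 2, `CSc1ccc(C2=NN(C(=S)Nc3ccccc3)C(c3ccc4c(c3)OCCO4)C2)cc1`; in this assay compound 2 gives no number but only a limit, > 200000 nM.

Compound 2 thus stands at the limit of > 200000 nM in this assay, at which 1 of the 2 values shown sits, so its growth inhibition is known only to be weaker than that of compound 1, not by how much. The two share a core and differ only in the group on the carbon that carries the double bond to nitrogen.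

Compound 3, `COc1ccccc1C1=NN(C(=S)Nc2ccccc2)C(c2ccc3c(c2)OCCO3)C1`, changes that same position once more: 2-methoxyphenyl in place of 4-(methylsulfanyl)phenyl on a carbon with a double bond to nitrogen. Among the compounds with values here, the single measured step, an at least 5.3-fold higher number from compound 1 to compound 2 (0.72 log units; beyond the scatter), shows that replacing a small fluoro by a methylsulfanyl group on that ring pushed the number past the limit of this assay. That step does not involve methoxy and cannot say where a methoxy-bearing ring will land. Because compound 1 gives 37600 nM, the number for compound 3 is expected to fall back toward a measurable value, an at least 2.8-fold lower number from compound 2 to compound 3 (0.45 log units; beyond the scatter), with wide uncertainty. Compound 3 is estimated at 70000 nM, within a range from 15000 nM to 300000 nM.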

Compound 3, concentration for 50% growth inhibition: 30500 nM
Compound 3: the middle estimate sits 2.3-fold (0.36 log units) above what was measured; measured number inside the range.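

In this assay, the position on the carbon with a double bond to nitrogen gives a measurable number with a ring other than 4-fluorophenyl, as changing 4-(methylsulfanyl)phenyl to 2-methoxyphenyl gives an at least 6.5-fold lower number from compound 2 to compound 3 (0.81 log units; beyond the scatter). The comparison with the fluoro-bearing ring reads a 1.2-fold lower number from compound 1 to compound 3 (0.09 log units; within the scatter), so 2-methoxyphenyl and 4-fluorophenyl cannot be told apart in this assay, even though the two rings carry different groups. Of the three rings, only the 4-(methylsulfanyl)phenyl ring of compound 2 ends at a limit and not at a number: the limit of > 200000 nM in this assay, at which 1 of the 3 values shown sits.

On these data alone, whether the loss seen with compound 2 belongs to the methylsulfanyl group itself or to its place on the ring stays open, and a 2-(methylsulfanyl)phenyl or a 4-methoxyphenyl ring would be needed to separate the two. Also open, as far as these compounds go, is how a ring bearing an amine or a carboxylic acid would read here, and whether any group at this position can bring growth inhibition much stronger than that of compound 1 and compound 3.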